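The compounds below may be only part of what the source reports. "The series", "measured", "known", "first", "only" and "open" are said of these compounds alone.

Three compounds share one core and differ only in the group on a saturated chain carbon bound to a saturated ring carbon. Compound 1 `COc1ccc2[nH]c(C(=O)N3CC(=O)N(Cc4ccccc4)[C@@H](CCc4ccccc4)C3)cc2c1` carries a benzyl there; in a physicochemical assay for solubility, read by spectrophotometry, in phosphate buffer, with a stated time of 2 h, at pH 7.4 (on this read-out higher numbers stand for higher solubility and lower numbers for lower solubility), compound 1 gives 4400 nM. Compound 2 `COc1ccc2[nH]c(C(=O)N3CC(=O)N(Cc4ccccc4)[C@@H](CN4CCCC4)C3)cc2c1` carries a pyrrolidin-1-yl, and in this assay compound 2 reaches only a limit, > 25000 nM, which is not a number. Compound 3 `COc1ccc2[nH]c(C(=O)N3CC(=O)N(Cc4ccccc4)[C@@H](COC(C)(C)C)C3)cc2c1` carries a tert-butoxy and in this assay gives 65500 nM, the highest of the two readable numbers, with compound 1 nearest after a 15-fold higher number from compound 1 to compound 3 (1.17 log units; beyond the scatter). The other steps are an at least 5.6-fold higher number from compound 1 to compound 2 (0.75 log units; beyond the scatter) and a step that the limit leaves unreadable from compound 2 to compound 3, both shaped by the limit (the limit of > 25000 nM in this assay, at which 1 of the 3 values shown sits).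

Compound 4 `COc1ccc2[nH]c(C(=O)N3CC(=O)N(Cc4ccccc4)[C@@H](COc4ccc(F)cc4)C3)cc2c1` differs from compound 3 by 4-fluorophenyl in place of tert-butyl on an oxygen on a saturated carbon. The step that bears most on this is the one that removed an aromatic ring, a 15-fold higher number from compound 1 to compound 3 (1.17 log units; beyond the scatter); compound 4 brings an aromatic ring back, so a downward step is expected. The step from compound 3 to compound 4 is expected to be a 6.6-fold lower number from compound 3 to compound 4 (0.82 log units; beyond the scatter). Compound 4 is estimated at 10000 nM, within a range from 3000 nM to 30000 nM.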

Compound 4, solubility: 17500 nM
For compound 4 the middle estimate is 1.8-fold (0.24 log units) below the measured one, within the range that was stated.
By their numbers in this assay, from the lowest: compound 1; then compound 4; then compound 3.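

In this assay, 4-fluorophenoxy in place of benzyl keeps an aromatic ring yet gives a 4.0-fold higher number from compound 1 to compound 4 (0.60 log units; beyond the scatter), so at this position the presence of an aromatic ring does not alone fix the number. Replacing tert-butyl on the oxygen with 4-fluorophenyl gives a 3.7-fold lower number from compound 3 to compound 4 (0.57 log units; beyond the scatter), which leaves the ring-free compound 3 with the highest readable number of the series. Compound 2 gives only a limit, so the step of an at least 1.4-fold lower number from compound 2 to compound 4 (0.15 log units; that floor lies within the scatter) fixes no order between the two: the limit of > 25000 nM in this assay, at which 1 of the 4 values shown sits.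

Going by these compounds, what stays open is how much of the drop from tert-butoxy comes from the ring and how much from the fluorine, which a plain phenoxy group would separate. A carboxylic acid or a longer chain at this place would show how far the number can move.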